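The compounds below may be only part of what the source reports. "The series", "measured", "known", "first", "only" and "open" are said of these compounds alone.

Working notes on the series. In a functional assay on RPMI 8402 cells (Homo sapiens) for cytotoxicity (on this read-out higher numbers stand for weaker inhibition and lower numbers for stronger inhibition), compound 1 `Cc1ccccc1-c1nc2cc(-c3nc4cc(C#N)ccc4[nH]3)ccc2[nH]1` gives 1200 nM, compound 2 `N#Cc1ccc2[nH]c(-c3ccc4[nH]c(-c5cccc6ccccc56)nc4c3)nc2c1` gives 650 nM and compound 3 `Cc1ccccc1-c1nc2cc(-c3nc4cc(C(N)=O)ccc4[nH]3)ccc2[nH]1` gives 8200 nM, the highest number of the three. The next entry, compound 4 `NC(=O)c1ccc2[nH]c(-c3ccc4[nH]c(-c5cccc6ccccc56)nc4c3)nc2c1`, departs from compound 3 by naphthalen-1-yl in place of 2-methylphenyl on an aromatic carbon. In words, naphthalen-1-yl stands in place of 2-methylphenyl on an aromatic carbon.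

The same exchange has been measured once, with cyano rather than carbamoyl on the other end of the molecule: a 1.8-fold lower number from compound 1 to compound 2 (0.27 log units; within the scatter). That step lies within the scatter. The other measured step, a 6.8-fold higher number from compound 1 to compound 3 (0.83 log units; beyond the scatter), is the change from cyano to carbamoyl and lies beyond the scatter. It shows how far compound 3 stands from compound 1. It says nothing direct about the aryl exchange. With this single precedent, no step beyond the scatter is expected in this assay. The estimate is a 1.8-fold lower number from compound 3 to compound 4 (0.26 log units; within the scatter). Compound 4 is expected at 4500 nM, with an estimated range from 1800 nM to 11000 nM.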

Compound 4, half-maximal inhibitory concentration: 3700 nM
Compound 4: the middle estimate sits 1.2-fold (0.09 log units) above what was measured, within the range that was stated.
By their numbers in this assay, from the lowest: compounds 2 and 1 (each within the scatter of the next); then compound 4; then compound 3.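

In this assay, the exchange of 2-methylphenyl for naphthalen-1-yl now has a second reading, a 2.2-fold lower number from compound 3 to compound 4 (0.35 log units; beyond the scatter), and its size carries over from the cyano compounds to the carbamoyl compounds: the same change on two cores in this assay, a 1.8-fold lower number (0.27 log units; within the scatter) from compound 1 to compound 2 and a 2.2-fold lower number (0.35 log units; beyond the scatter) from compound 3 to compound 4, 1.2-fold (0.08 log units) apart, within the scatter of two such steps The change from cyano to carbamoyl, now also read with naphthalen-1-yl in place, gives a 5.7-fold higher number from compound 2 to compound 4 (0.76 log units; beyond the scatter), and it too repeats: the same change on two cores in this assay, a 6.8-fold higher number (0.83 log units; beyond the scatter) from compound 1 to compound 3 and a 5.7-fold higher number (0.76 log units; beyond the scatter) from compound 2 to compound 4, 1.2-fold (0.08 log units) apart, within the scatter of two such steps Across these four compounds the two changes behave as independent steps, and neither alters the size of the other beyond the scatter.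

Going by these compounds, what a saturated ring such as cyclohexyl would give on the aromatic carbon between two ring nitrogen atoms stays open. So does the outcome of a carboxylic acid or an aminomethyl group in place of cyano or carbamoyl.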